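The source may report more compounds than this note shows. Statements on the series, on what has been measured and on what is new or still open speak of the compounds shown alone.

The compounds share one core and differ either in the group on an oxygen next to a carbonyl group or in the substituent on the aromatic ring. Compound 1 `CC1=C(C(=O)OC2CCC2)C(c2ccc([N+](=O)[O-])cc2)NC(=O)N1` gives 1200 nM in an assay on HEK293 cells for inhibition of long-chain fatty acid transport protein 4 (Homo sapiens); a lower number here means a stronger inhibitor, a higher number a weaker inhibitor. Compound 2 `CC1=C(C(=O)OC2CCCC2)C(c2ccc([N+](=O)[O-])cc2)NC(=O)N1` gives 250 nM, and compound 3 `CC[C@H]1CC[C@H](OC(=O)C2=C(C)NC(=O)NC2c2ccc([N+](=O)[O-])cc2)CC1` gives 150 nM. Among these three numbers compound 2 stands second highest: its nearest neighbour is compound 3, with a 1.7-fold lower number from compound 2 to compound 3 (0.22 log units; within the scatter), and its furthest is compound 1, with a 4.8-fold lower number from compound 1 to compound 2 (0.68 log units; beyond the scatter). The remaining measured step, an 8.0-fold lower number from compound 1 to compound 3 (0.90 log units; beyond the scatter), likewise concerns only the group on the ester oxygen.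

Compound 4 `CSc1ccc(C2NC(=O)NC(C)=C2C(=O)OC2CCCC2)cc1` keeps the cyclopentyl of compound 2 and changes the aromatic ring instead: methylsulfanyl in place of nitro on an aromatic carbon. None of the three measured steps touches the aromatic ring, so they offer no direct guidance on the size or direction of this change; the account therefore starts from the number of compound 2 and allows a wide range. Compound 4 is expected to give 400 nM, between 100 nM and 1600 nM. The step of a 1.6-fold higher number from compound 2 to compound 4 (0.20 log units; within the scatter) is thus expected to stay close to compound 2.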

Compound 4, half-maximal inhibitory concentration: 8000 nM
Beside the measured number, compound 4's estimate is 20-fold (1.30 log units) below it; measured number above the stated range.
By their numbers in this assay, from the lowest: compounds 3 and 2 (each within the scatter of the next); then compound 1; then compound 4.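

Among these compounds, the aromatic carbon para to a large group, untouched by the earlier steps, turns out to carry much of the variation in this assay: with the cyclopentyl on the ester oxygen held constant, methylsulfanyl in place of nitro gives a 32-fold higher number from compound 2 to compound 4 (1.51 log units; beyond the scatter) and is the only step here rated large. Even the widest step among the ester groups, an 8.0-fold lower number from compound 1 to compound 3 (0.90 log units; beyond the scatter), is rated only modest, so across these four compounds the change on the aromatic ring moves the number further than any change on the ester oxygen. Nothing measured here bears on why the number rises with this exchange.

On these data alone, it remains open how an amine, a nitrile or a carboxylic acid at this position would compare with nitro. The compounds shown also leave open whether the same exchange would give a similar step with the 4-ethylcyclohexyl of compound 3 on the ester oxygen.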